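The source may report more compounds than this note shows. Statements on the series, on what has been measured and on what is new or still open speak of the compounds shown alone.

Working notes on the series. Compound 1 `CC(C)c1onc(-c2c(Cl)cccc2Cl)c1COc1ccc(-c2nc3ccc(C(=O)O)cc3n2CC(C)(C)C)cc1` is the reference here. In an assay on HEK-293T cells for antagonist activity at vitamin D3 receptor (Homo sapiens), read by a luciferase reporter, with a stated time of 24 h (a lower number here means a stronger inhibitor, a higher number a weaker inhibitor), compound 1 gives 861 nM, the lowest of the three numbers measured. Compound 3 `CC(C)c1onc(-c2c(Cl)cccc2Cl)c1COc1ccc(-c2nc3ccc(C(=O)O)cc3n2C2CCCCCC2)cc1` gives 921 nM in this assay and is the nearest to compound 1: a 1.1-fold higher number from compound 1 to compound 3 (0.03 log units; within the scatter). Compound 2 `CC(C)c1onc(-c2c(Cl)cccc2Cl)c1COc1ccc(-c2nc3ccc(C(=O)O)cc3n2C2CC2)cc1` gives 3200 nM in this assay and is the furthest: a 3.7-fold higher number from compound 1 to compound 2 (0.57 log units; beyond the scatter). Between the two ring-bearing compounds the step is a 3.5-fold lower number from compound 2 to compound 3 (0.54 log units; beyond the scatter).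

The next compound, compound 4 `CC(C)c1onc(-c2c(Cl)cccc2Cl)c1COc1ccc(-c2nc3ccc(C(=O)O)cc3n2C2CCCC2)cc1`, is not yet measured. It differs from compound 1 in one place: cyclopentyl in place of neopentyl on an aromatic nitrogen

The bearing steps are the other two replacements of neopentyl on the same aromatic nitrogen. Cyclopropyl cost modestly, cycloheptyl cost nothing beyond the scatter. Cyclopentyl lies between those two in the series of rings tried, so the expectation for compound 4 in this assay is a number between those of compound 2 and compound 3, leaning toward the latter, a step of a 1.5-fold higher number from compound 1 to compound 4 (0.18 log units; within the scatter) that is expected to be within or just beyond the scatter. The estimate for compound 4 in this assay is therefore 1300 nM, with a range from 550 nM to 3200 nM.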

Compound 4, half-maximal inhibitory concentration: 929 nM
Compound 4: the middle estimate sits 1.4-fold (0.15 log units) above what was measured; low and high end bracket the measured number.
By their numbers in this assay, from the lowest: compounds 1, 3 and 4 (each within the scatter of the next); then compound 2.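

In this assay, among these compounds, cyclopentyl on the aromatic nitrogen shows no step from neopentyl (a 1.1-fold higher number from compound 1 to compound 4 (0.03 log units; within the scatter)), so closing the same count of five carbons into a ring leaves the number within the scatter. Cyclopentyl also stands level with cycloheptyl (a 1.0-fold higher number from compound 3 to compound 4 (0.00 log units; within the scatter)) and apart from cyclopropyl (a 3.4-fold lower number from compound 2 to compound 4 (0.54 log units; beyond the scatter)), so among the rings shown only the cyclopropyl of compound 2 departs, and going from the five-membered ring to cycloheptyl changes nothing readable. Nothing available bears on why these groups give these numbers.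

Still open, going by these compounds, is whether cyclobutyl reads with cyclopropyl or with cyclopentyl. Also open, on these data alone, is whether a tetrahydropyran ring, a piperidine ring carrying an amine, or a straight butyl chain at this nitrogen would stay level with compound 1.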